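Swapping the chlorine position on a weak cytotoxic pyridine

The source may hold more compounds than are shown below. What is called first, only, known or untested is meant among the compounds shown, and "the series" means these compounds.

Measured compounds:
- Compound 1, `Oc1cccc(-c2cc(-c3cccnc3)nc(-c3cccc(Cl)c3)c2)c1`: "not determined" (no result reported)
- Compound 2, `Oc1cccc(-c2cc(-c3ccc(Cl)cc3)nc(-c3cccnc3)c2)c1`: 18100 nM
- Compound 3, `Oc1cccc(-c2cc(-c3cccc(Cl)c3)nc(-c3ccccn3)c2)c1`: "not determined" (no result reported)

Three compounds share a central pyridine ring carrying a 3-hydroxyphenyl group, a chlorophenyl group and a second pyridine, and differ in how these are arranged. In a functional assay on T47D cells (Homo sapiens) for cytotoxicity, read by CCK-8 assay and cell counting, with a stated time of 2 days (a higher number here means a weaker inhibitor, a lower number a stronger inhibitor), compound 2 gives 18100 nM, a weak effect. In this assay compound 1 gives "not determined" (no result reported) and compound 3 gives "not determined" (no result reported), so compound 3 stands without any number, and the set holds no comparison between two measured neighbours from which the size of a single change could be read.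

The unmeasured compound 4, `Oc1cccc(-c2cc(-c3ccc(Cl)cc3)nc(-c3ccccn3)c2)c1`, is built from compound 3 by 4-chlorophenyl in place of 3-chlorophenyl on an aromatic carbon. Among the compounds with values here, no measured pair shows the effect of this change, so its size and direction are unknown; the only anchor is that compound 4 carries the same 4-chlorophenyl group as compound 2, which gives 18100 nM in this assay. On that basis compound 4 is expected to be a similarly weak inhibitor, with an estimate of 20000 nM and a likely range from 5000 nM to 80000 nM.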

Compound 4, half-maximal inhibitory concentration: 13900 nM
Compound 4: middle estimate off by 1.4-fold (0.16 log units), on the high side, and the stated range covers the measured number.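

Within the data shown here, the first comparison of two measured neighbours in this set comes from pyridin-2-yl in place of pyridin-3-yl with the 4-chlorophenyl group kept, and in this assay it gives a 1.3-fold lower number from compound 2 to compound 4 (0.11 log units; within the scatter). This step lies within the usual scatter of repeated measurements, so the assay does not tell these two pyridine attachments apart, and with the 4-chlorophenyl group present, both compounds sit in the same weak range. Nothing available explains why this swap leaves the read-out so flat.

The chlorine shift itself, from 3-chlorophenyl to 4-chlorophenyl, remains unreadable, since compound 3 has no number, and the same gap keeps compound 1 out of every comparison, so whether the chlorine position matters at all stays unsettled. Also open, going by these compounds, is whether a pyridin-4-yl group in place of the second pyridine, or an amine or a carboxylic acid in place of the chlorine, would move the number beyond the scatter, since the compounds here cover only small rearrangements of the same three groups.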